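A few compounds are considered here, and "the series" means these few. Any claim that something is new, unique, unknown or untested is made for them only; others in the source may bear on it.

Of the compounds shown here, three with a shared core have been tested in a functional assay on HCT-116 cells (Homo sapiens) for cytotoxicity, read by MTT assay, with a stated time of 72 h; a higher number here means a weaker inhibitor, a lower number a stronger inhibitor. In this test compound 1 `CN(C)CCCCCn1c2c(c3ccccc31)C(=O)c1c[n+]([O-])c3ccccc3c1C2=O` gives 470 nM, compound 2 `CN1CCN(CCCCn2c3c(c4ccccc42)C(=O)c2c[n+]([O-])c4ccccc4c2C3=O)CC1` gives 10 nM, and compound 3 `O=C1c2c[n+]([O-])c3ccccc3c2C(=O)c2c1c1ccccc1n2CCCCN1CCNCC1` gives 700 nM. Compound 3 cannot be told apart from compound 1, as the step of a 1.5-fold higher number from compound 1 to compound 3 (0.17 log units; within the scatter) shows, but it stands far from compound 2.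

The next structure, compound 4 `CCCCN1CCN(CCCCn2c3c(c4ccccc42)C(=O)c2c[n+]([O-])c4ccccc4c2C3=O)CC1`, differs from compound 3 in a single place: butyl in place of hydrogen on an amine nitrogen in a ring. In words, this puts butyl in place of hydrogen on an amine nitrogen in a ring. No butyl group on this nitrogen has been measured yet, so the best guide is the same nitrogen carrying methyl. Removing that methyl gives a 70-fold higher number from compound 2 to compound 3 (1.85 log units; beyond the scatter), a large step, and read backwards it suggests that an alkyl group here could lower the number. The step of a 47-fold lower number from compound 1 to compound 2 (1.67 log units; beyond the scatter) is also large, but it replaces the whole amine end of the chain, so it says less about this change.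

Butyl is not methyl, and compound 2 at 10 nM is the only example, so only part of that drop is expected to carry over. The expected outcome is a clear move towards a stronger inhibitor, a 12-fold lower number from compound 3 to compound 4 (1.07 log units; beyond the scatter). For compound 4 the estimated value is 60 nM, with an expected range from 12 nM to 350 nM.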

Compound 4, half-maximal inhibitory concentration: 1920 nM
Compound 4: middle estimate off by 32-fold (1.51 log units), on the low side; the whole stated range lies below it.
By their numbers in this assay, from the lowest: compound 2; then compounds 1 and 3 (each within the scatter of the next); then compound 4.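

In this assay, an alkyl group on this amine nitrogen does not act as a single class: butyl gives a 2.7-fold higher number from compound 3 to compound 4 (0.44 log units; beyond the scatter), the opposite direction to the large drop seen with methyl. The length of the group therefore matters greatly here, as a 190-fold higher number from compound 2 to compound 4 (2.28 log units; beyond the scatter) shows for two compounds that differ only in this group, and the methyl result of compound 2 cannot be taken as a guide to larger alkyl groups. The 4-butylpiperazin-1-yl end also does worse than the dimethylamino end of compound 1, with a 4.1-fold higher number from compound 1 to compound 4 (0.61 log units; beyond the scatter), which makes compound 4 the weakest inhibitor of the set, and no accompanying measurement accounts for this reversal.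

The compounds shown leave open how the number changes between methyl and butyl, and ethyl or propyl on the same nitrogen would show whether it rises gradually or jumps sharply. They also leave open whether the loss belongs to the length of the chain itself, which a branched group of the same size, such as isobutyl, or a ring such as cyclopropylmethyl could help to separate.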